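The compounds below may be only part of what the source reports. "The series", "measured", "known", "first", "only" and "open" are said of these compounds alone.

Compounds measured so far:
- compound 1 `COc1cc(/C=C/c2nc(NC3CC3)c3sccc3n2)cc(OC)c1OC`: > 50000 nM
- compound 2 `COc1cc(/C=C/c2nc(Nc3ccc(C(F)(F)F)cc3)c3sccc3n2)cc(OC)c1OC`: > 50000 nM
- compound 3 `COc1cc(/C=C/c2nc(NCc3ccccc3)c3sccc3n2)cc(OC)c1OC`: > 50000 nM

Three compounds sharing one core were tested in an ADME assay on RAW264.7 cells (Mus musculus) for cytotoxicity, read by MTT assay; on this read-out lower numbers stand for stronger inhibition and higher numbers for weaker inhibition. Compound 1 gives > 50000 nM, which is a limit of the assay rather than a number. Compound 2 likewise gives > 50000 nM, again only a limit. Compound 3 also gives > 50000 nM, a limit as well. Compound 1 therefore stands at the limit, and so do both other compounds, as the summary the limit of > 50000 nM in this assay, at which 3 of the 3 values shown sit, states.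

The unmeasured compound 4 `COc1cc(/C=C/c2nc(NCc3ccc(Cl)cc3)c3sccc3n2)cc(OC)c1OC` differs from compound 1 in one place: 4-chlorobenzyl in place of cyclopropyl on a nitrogen on an aromatic ring. The measured steps that bear on this change are a step that the two limits leave unreadable from compound 1 to compound 2 and a step that the two limits leave unreadable from compound 1 to compound 3, and between the two larger groups a step that the two limits leave unreadable from compound 2 to compound 3; none can be read in size, since every value is a limit. No direction can be expected beyond the scatter in this assay; the most likely outcome is another limit.

For compound 4 the estimate is 80000 nM, within 30000 nM to 300000 nM. The expected step is a step that the limit leaves unreadable from compound 1 to compound 4.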

Compound 4, half-maximal inhibitory concentration: > 50000 nM
Compound 4 ended at the assay's limit; the forecaster's own chance of this, stated with the estimate: 85%; the middle value does not contradict the limit.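

Within the data shown here, compound 4 gives only a limit rather than a number, as do compound 1, compound 2 and compound 3, so no step among them can be read in size: the limit of > 50000 nM in this assay, at which 4 of the 4 values shown sit. The compounds shown leave open whether the group on this nitrogen changes the cytotoxicity at all.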